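This account rests on a few compounds, and the source may have more. Where it says the series, first, only, none or still open, it means among the compounds named here.

Series built on the shared core of compound 1 `COc1ccc(-c2nc3cc(C(C)O)ccc3[nH]2)cc1`. In an ADME assay on BHK-21 cells (Mesocricetus auratus) for cytotoxicity, read by MTT assay (a lower number here means that less compound is tolerated, a higher number that more compound is tolerated), compound 1 gives only a limit, > 100000 nM. Compound 2 `COc1ccc(-c2nc3cc(C(C)O)ccc3[nH]2)c(OC)c1` carries methoxy in place of hydrogen on an aromatic carbon. In this assay compound 2 likewise gives a limit, > 100000 nM. Between them stands a step that the two limits leave unreadable from compound 1 to compound 2. Compound 3 `COc1ccc(-c2nc3cc(/C(C)=N/NC(N)=S)ccc3[nH]2)cc1` differs from compound 1 by a group of 7 heavy atoms (3 carbon, 3 nitrogen, 1 sulfur; no ring) in place of a group of 3 heavy atoms (2 carbon, 1 oxygen; no ring), on an aromatic carbon. In this assay compound 3 gives 13000 nM, which is an at least 7.6-fold lower number from compound 1 to compound 3 (0.88 log units; beyond the scatter), and it is the one number shown, the other two values sitting at the limit of > 100000 nM in this assay, at which 2 of the 3 values shown sit.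

Compound 4 `COc1ccc(-c2nc3cc(/C(C)=N/NC(N)=S)ccc3[nH]2)c(OC)c1` is not yet measured. It carries methoxy in place of hydrogen on an aromatic carbon, the same change as from compound 1 to compound 2, on the same kind of place. That earlier step is not readable, so the expectation rests on compound 3 at 13000 nM. For compound 4 the expected step is no change at the digits printed from compound 3 to compound 4 (within the scatter). Compound 4 is estimated at 13000 nM, expected between 5000 nM and 40000 nM.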

Compound 4, half-maximal cytotoxic concentration: 28000 nM
For compound 4 the middle estimate is 2.2-fold (0.33 log units) below the measured one; the range from low to high includes it.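

The swap of the group of 3 heavy atoms for the group of 7 heavy atoms gives an at least 3.5-fold lower number from compound 2 to compound 4 (0.55 log units; beyond the scatter) in this assay. The direction thus holds on both cores, but the sizes cannot be compared: the same change on two cores in this assay, an at least 7.6-fold lower number (0.88 log units; beyond the scatter) from compound 1 to compound 3 and an at least 3.5-fold lower number (0.55 log units; beyond the scatter) from compound 2 to compound 4; the limit leaves it open whether they differ

The methoxy change reads as a 2.2-fold higher number from compound 3 to compound 4 (0.33 log units; beyond the scatter), while its step from compound 1 to compound 2 cannot be read: the limit of > 100000 nM in this assay, at which 2 of the 4 values shown sit.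

As far as these compounds go, whether an amine or a carboxylic acid in place of that methoxy would give a similar step stays open. So does whether a longer chain in place of the group of 7 heavy atoms would keep the same direction on both cores.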